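The source may report more compounds than this note shows. Statements on the series, on what has been measured and on what is new or still open speak of the compounds shown alone.

Of the compounds shown here, three have so far been tested in an ADME assay on PBMC cells (Homo sapiens) for cytotoxicity, with a stated time of 5 days; a lower number here means a stronger inhibitor, a higher number a weaker inhibitor. Compound 1 `Cc1ccsc1C(=O)/C=C/c1ccc(N2CCCCC2)cc1` gives 26400 nM, and compound 2 `O=C(/C=C/c1ccc(N2CCCCC2)cc1)c1cc(Cl)sc1Cl` gives 42800 nM. Between them lies a single change on the carbonyl carbon, 2,5-dichlorothiophen-3-yl in place of 3-methylthiophen-2-yl, and the result was a 1.6-fold higher number from compound 1 to compound 2 (0.21 log units; within the scatter). Compound 3 `c1csc(C2=NNC(c3ccc(N4CCCCC4)cc3)C2)c1` belongs to a different core and gives 20800 nM. Against compound 1 it sits within the scatter; against compound 2 the gap is beyond the scatter, with compound 2 giving the higher number.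

Compound 4 `Brc1ccc(C2=NNC(c3ccc(N4CCCCC4)cc3)C2)s1` shares the core of compound 3 and differs from it in one place: bromo in place of hydrogen on an aromatic carbon. Among the compounds with values here, no measured pair shows a bromo entering a thiophene ring on this core. Within the data shown here, the only step available, from compound 1 to compound 2, swaps substituents on a thiophene ring of a different core and stayed within the scatter, so it offers only weak guidance. On that basis little movement is expected in this assay, and the step from compound 3 to compound 4 is estimated as a 1.2-fold lower number from compound 3 to compound 4 (0.06 log units; within the scatter). Compound 4 is therefore expected to give about 18000 nM, within a range from 7000 nM to 45000 nM.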

Compound 4, half-maximal inhibitory concentration: 80000 nM
Beside the measured number, compound 4's estimate is 4.4-fold (0.65 log units) below it; measured number above the stated range.
By their numbers in this assay, from the lowest: compounds 3, 1, 2 and 4 (each within the scatter of the next, the first and the last beyond it).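

In this assay, replacing thiophen-2-yl with 5-bromothiophen-2-yl gives a 3.8-fold higher number from compound 3 to compound 4 (0.59 log units; beyond the scatter) and so makes compound 4 the weaker inhibitor of this pair, which shows that a single bromo at this place, next to the ring sulfur, can move the number beyond the scatter. The earlier thiophene change, a 1.6-fold higher number from compound 1 to compound 2 (0.21 log units; within the scatter), gave no such signal, but it exchanged one substituted thiophene for another on a different core, whereas the new pair isolates one added atom at one ring position. The data shown offer no measurement that accounts for the rise, so it stands here as an observed result without an established cause.

As far as these compounds go, it remains open whether this shift belongs to bromo specifically or would also appear with another group on the same carbon, such as chloro, methyl, methoxy or an amine. From the compounds shown here alone, it is equally open whether bromo at this ring position would produce a similar step on the core of compound 1, where the thiophene is attached to a carbonyl carbon.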